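The source may hold more compounds than are shown below. What is called first, only, known or untested is meant among the compounds shown, and "the series" means these compounds.

Series notes. Compound 1 `CN(C)c1cccc(Oc2ccc3c(NCCCNCc4ccco4)ccnc3c2)c1` and compound 2 `Fc1ccc(Oc2ccc3c(NCCCNCc4ccco4)ccnc3c2)cc1` share one core; compound 3 `COc1cccc(CNCCCNc2ccnc3cc(Oc4cccc(N(C)C)c4)ccc23)c1O` carries the other, and compound 4 `COc1cccc(CNCCCNc2ccnc3cc(Oc4ccc(F)cc4)ccc23)c1O` is the pairing of that core with the aryl ether of compound 2. In an ADME assay on HepG2 cells (Homo sapiens) for cytotoxicity, read by luminescence, CellTiter-Glo and ATP content, with a stated time of 72 h (on this read-out higher numbers stand for an effect only at larger amounts of compound and lower numbers for an effect already at smaller amounts), compound 1 gives 16000 nM, compound 2 gives 16000 nM and compound 3 gives 7300 nM. The two cores differ as 2-hydroxy-3-methoxyphenyl in place of furan-2-yl on a saturated chain carbon bound to an amine nitrogen, a step of a 2.2-fold lower number from compound 1 to compound 3 (0.34 log units; beyond the scatter). The exchange 4-fluorophenyl in place of 3-(dimethylamino)phenyl on an oxygen on an aromatic ring gave no change at the digits printed from compound 1 to compound 2 (within the scatter). The exchange 4-fluorophenyl in place of 3-(dimethylamino)phenyl on an oxygen on an aromatic ring is the same change, made at the same place, on the core of compound 3. Going by the values given here, because the first instance of it read no change at the digits printed from compound 1 to compound 2 (within the scatter), the step from compound 3 to compound 4 is expected to be a 1.0-fold higher number from compound 3 to compound 4 (0.01 log units; within the scatter) in this assay, with only one prior instance as support. Compound 4 is therefore estimated at 7500 nM, likely between 3500 nM and 16000 nM.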

Compound 4, half-maximal effective concentration: 11000 nM
Estimate against measurement, compound 4: 1.5-fold (0.17 log units) below; low and high end bracket the measured number.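

In this assay the exchange of 3-(dimethylamino)phenyl for 4-fluorophenyl carries from one core to the other with no gap beyond the scatter, the new instance being a 1.5-fold higher number from compound 3 to compound 4 (0.18 log units; within the scatter): the same change on two cores in this assay, no change at the digits printed (within the scatter) from compound 1 to compound 2 and a 1.5-fold higher number (0.18 log units; within the scatter) from compound 3 to compound 4, 1.5-fold (0.18 log units) apart, within the scatter of two such steps. The exchange of furan-2-yl for 2-hydroxy-3-methoxyphenyl, now a 1.5-fold lower number from compound 2 to compound 4 (0.16 log units; within the scatter), also carries across the two aryl ethers: the same change on two cores in this assay, a 2.2-fold lower number (0.34 log units; beyond the scatter) from compound 1 to compound 3 and a 1.5-fold lower number (0.16 log units; within the scatter) from compound 2 to compound 4, 1.5-fold (0.18 log units) apart, within the scatter of two such steps. Going by these compounds alone, with only two instances of each change, these pairs show no detectable dependence on the partner group, but they do not establish that either step transfers to other compounds.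

Still open, going by these compounds, is whether a pyridine or a piperidine in place of furan-2-yl follows the same pattern. The same question applies to a carboxylic acid on the aryl ether or a longer chain.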